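Methyl for methoxy on an inactive thiophene analogue

The compounds below may be only part of what the source reports. "The series", "measured", "known", "first", "only" and "open" are said of these compounds alone.

Compound 1 `COc1ccc(Nc2sc(C(=O)c3ccc(OC)cc3)c(C)c2C(=O)O)cc1` gives 23.5% in a functional assay, with a stated time of 150 min, tested at 10 ug/mL; a higher number here means a stronger effect of the compound at the concentration tested, a lower number a weaker effect. Compound 2 `COc1ccc(C(=O)c2sc(Nc3ccc(Cl)cc3)c(C(=O)O)c2C)cc1` is reported in this assay as "not active" (no number reported), without a number, so it stands only as lacking measurable activity at the concentration tested. Compound 3 `Cc1ccc(C(=O)c2sc(Nc3ccc(Cl)cc3)c(C(=O)O)c2C)cc1` differs from compound 2 by one change: methyl in place of methoxy on an aromatic carbon, placed on an aromatic carbon of a six-membered aromatic ring of carbon only, para to a large group. Among the compounds with values here, with no step between measured compounds to lean on, any shift in this assay is expected to be small, likely none beyond the scatter. Compound 3 is therefore expected to show 10%, in a range from 0% to 30%.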

Compound 3, a percentage reported as activity, at one concentration (the size of the read-out at that concentration, not a potency): "not active" (no number reported)
No number was reported for compound 3, so the estimate cannot be set against anything.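

Compound 2 and compound 3 are both reported as not active in this assay, without a number, so no step can be read between them. From the compounds shown here alone, whether the change from 4-methoxyphenyl to 4-methylphenyl alters activity at all remains open. Nothing shown offers an explanation for this result.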